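Azole replacements for piperazin-1-yl on the shared core

The source may hold more compounds than are shown below. What is called first, only, known or untested is meant among the compounds shown, and "the series" means these compounds.

Measured in a functional assay on HUVEC cells (Homo sapiens), read by scintillation counting and thymidine incorporation, with a stated time of 24 h; a higher number here means a weaker inhibitor, a lower number a stronger inhibitor:
compound 1 `CCC(C)n1ncn(-c2ccc(N3CCN(c4ccc(OC[C@@H]5CO[C@@](CN6CCNCC6)(c6ccc(Cl)cc6Cl)O5)cc4)CC3)cc2)c1=O`: 608 nM
compound 2 `CCC(C)n1ncn(-c2ccc(N3CCN(c4ccc(OC[C@@H]5CO[C@@](Cn6cnc(C)n6)(c6ccc(Cl)cc6Cl)O5)cc4)CC3)cc2)c1=O`: 272 nM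
compound 3 `CCC(C)n1ncn(-c2ccc(N3CCN(c4ccc(OC[C@@H]5CO[C@@](Cn6ccnc6C)(c6ccc(Cl)cc6Cl)O5)cc4)CC3)cc2)c1=O`: 173 nM

Compound 1 gives the highest of the three numbers in this assay; the nearest is compound 2 and the furthest compound 3. Compound 4 `CCC(C)n1ncn(-c2ccc(N3CCN(c4ccc(OC[C@@H]5CO[C@@](Cn6ccnc6C(C)C)(c6ccc(Cl)cc6Cl)O5)cc4)CC3)cc2)c1=O` has not been measured. Its difference from compound 1 is 2-isopropyl-1H-imidazol-1-yl in place of piperazin-1-yl on a saturated chain carbon bound to a saturated ring carbon. Among the measured compounds shown here, two measured steps bear on it: a 2.2-fold lower number from compound 1 to compound 2 (0.35 log units; beyond the scatter) and a 3.5-fold lower number from compound 1 to compound 3 (0.55 log units; beyond the scatter), both moves from piperazin-1-yl to a five-membered aromatic ring with 2 hetero atoms. Between the two azoles, a 1.6-fold lower number from compound 2 to compound 3 (0.20 log units; within the scatter). Because compound 3 gives 173 nM with 2-methyl-1H-imidazol-1-yl and compound 4 differs only by isopropyl in place of methyl, compound 4 is expected to show a 3.4-fold lower number from compound 1 to compound 4 (0.53 log units; beyond the scatter). Compound 4 is thus estimated at 180 nM, in the range 70 nM to 450 nM.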

Compound 4, half-maximal inhibitory concentration: 84 nM
Compound 4: middle estimate off by 2.1-fold (0.33 log units), on the high side; low and high end bracket the measured number.
By their numbers in this assay, from the lowest: compound 4; then compounds 3 and 2 (each within the scatter of the next); then compound 1.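

Within the imidazole series, enlarging the substituent on the aromatic carbon still changes the result in this assay: isopropyl in place of methyl gives a 2.1-fold lower number from compound 3 to compound 4 (0.31 log units; beyond the scatter). Compound 2 and compound 3 lie within the scatter of each other, yet the isopropyl compound separates from the triazole, with a 3.2-fold lower number from compound 2 to compound 4 (0.51 log units; beyond the scatter), and the distance from the piperazin-1-yl compound widens to a 7.2-fold lower number from compound 1 to compound 4 (0.86 log units; beyond the scatter). No measurement here accounts for these steps. Still open, on these data alone, is whether tert-butyl or phenyl in place of isopropyl on that aromatic carbon lowers the number further or reverses the step.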